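Swapping trifluoromethyl for fluoro in compound 3

A few compounds are considered here, and "the series" means these few. Any claim that something is new, unique, unknown or untested is made for them only; others in the source may bear on it.

Of the compounds shown here, three that share one core have been tested in a functional assay on KB cells (Homo sapiens) for antiproliferative activity, read by sulforhodamine B assay, with a stated time of 3 days; a higher number here means that more compound is needed for the effect, a lower number that less compound is needed. Compound 1 (`CCOc1ccc(-c2cc(=O)c3c(o2)C(CC)(CC)C(=O)C(CC)=C3O)cc1`) gives > 52.4 uM, which is a limit of the assay and not a number. Compound 2 (`CCC1=C(O)c2c(oc(-c3ccc(CBr)cc3)cc2=O)C(CC)(CC)C1=O`) gives > 46.5 uM, which is also a limit and not a number. Going by the values given here, compound 3 (`CCC1=C(O)c2c(oc(-c3ccccc3C(F)(F)F)cc2=O)C(CC)(CC)C1=O`) gives 45.6 uM, the only true number of the three, so its rank against the other two cannot be read.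

Compound 4 (`CCC1=C(O)c2c(oc(-c3ccccc3F)cc2=O)C(CC)(CC)C1=O`) differs from compound 3 in one place: fluoro in place of trifluoromethyl on an aromatic carbon.

Among the compounds with values here, only one measured step changes a single place, a step that the two limits leave unreadable from compound 1 to compound 2. It involves different groups and has no readable size, so it offers no measure for this swap. With no measured size to carry over, no step beyond the usual scatter is expected in this assay, in either direction. The estimated change is a 1.0-fold lower number from compound 3 to compound 4 (0.01 log units; within the scatter). The estimate for compound 4 is 45 uM, with an expected range from 22 uM to 60 uM.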

Compound 4, concentration for half-maximal effect: > 56.2 uM
Compound 4 gave a limit, no number; the forecaster's own chance of this, stated with the estimate: 50%; at least 1.2-fold (0.09 log units) between middle value and limit.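

In this assay, going by these compounds alone, this is the first step at a place ortho to a large group that can be read at all, though only from one side: an at least 1.2-fold higher number from compound 3 to compound 4 (0.09 log units; that floor lies within the scatter). Compound 4 stands as a limit and not a number: the limit of > 56.2 uM in this assay, at which 1 of the 4 values shown sits. Fluoro in place of trifluoromethyl on this aromatic carbon therefore brought no lower number, yet the floor of the step is too small to show a real rise, and the steps from compound 1 and from compound 2 to compound 4 cannot be read, as each joins two limits.

As far as these compounds go, how far compound 4 lies past its limit stays open, so the true size of this step could turn out small or large. Also open, from the compounds shown here alone, is whether an amine or a carboxylic acid on this same aromatic carbon would bring the number down, since the two groups compared here give no sign of a lower number at this place.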